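This account rests on a few compounds, and the source may have more. Where it says the series, first, only, none or still open, it means among the compounds named here.

Going by the values given here, compound 2 `Cc1cc(C#N)cc(C)c1Oc1nc(Nc2ccc(C#N)cc2)ncc1-c1ccc(-c2ccccc2)cc1` is one of only two compounds so far measured in an ADME assay on MT4 cells (Homo sapiens) for cytotoxicity, read by MTT assay, with a stated time of 5 days; a higher number here means that more compound is tolerated, a lower number that less compound is tolerated. In this assay compound 2 gives > 253000 nM, which is a limit of the assay rather than a number. Compound 1 `Cc1cc(C#N)cc(C)c1Oc1nc(Nc2ccc(C#N)cc2)ncc1-c1ccco1` shares the same core. In this assay compound 1 gives > 306000 nM, again a limit and not a number. Both values sit at limits (the limit of > 253000 nM in this assay, at which 1 of the 2 values shown sits, (the limit of > 306000 nM in this assay, at which 1 of the 2 values shown sits)), so the step that the two limits leave unreadable from compound 1 to compound 2 cannot be sized in either direction. Compound 3 `Cc1cc(C#N)cc(C)c1Oc1nc(Nc2ccc(C#N)cc2)ncc1-c1cccnc1` has not yet been measured; its change from compound 2 is pyridin-3-yl in place of 4-phenylphenyl on an aromatic carbon. Among the compounds with values here, no readable measured step bears on this change, so the only guide is that every value seen so far sits at a limit. Compound 3 is therefore expected to be tolerated up to the top of the tested range in this assay. The estimate for compound 3 is 300000 nM with a range from 100000 nM to 1000000 nM. That estimate means an expected step that the limit leaves unreadable from compound 2 to compound 3, within the scatter.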

Compound 3, half-maximal cytotoxic concentration: 13500 nM
For compound 3 the middle estimate is 22-fold (1.35 log units) above the measured one; measured number outside the range, below it.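

In this assay the group on this aromatic carbon, para to the (4-cyanophenyl)amino group, now proves to matter: pyridin-3-yl gives an at least 18-fold lower number from compound 2 to compound 3 (1.27 log units; beyond the scatter) and, set against furan-2-yl, an at least 22-fold lower number from compound 1 to compound 3 (1.35 log units; beyond the scatter) so less compound is tolerated with this ring than with either earlier group. The first of these steps is only a minimum size, because compound 2 stands at a limit: the limit of > 253000 nM in this assay, at which 1 of the 3 values shown sits. The second is a minimum size as well, because compound 1 also stands at a limit: the limit of > 306000 nM in this assay, at which 1 of the 3 values shown sits.

On these data alone, whether the lower number goes with the ring nitrogen of pyridin-3-yl stays open, and a plain phenyl on this carbon would be the direct comparison. Also open, as far as these compounds go, is how in this assay an amine or a short alkyl chain would fare at this position.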